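The source may hold more compounds than are shown below. What is called first, only, known or untested is meant among the compounds shown, and "the series" means these compounds.

Measured so far in a functional assay on RAW264.7 cells (Mus musculus) for inhibition; on this read-out higher numbers stand for weaker inhibition and lower numbers for stronger inhibition:
- compound 1 `CCOC(=O)C1=CCCCC1S(=O)(=O)Nc1ccc(Cl)cc1F`: 160 nM
- compound 2 `CCOC(=O)C1=CCCCC1S(=O)(=O)Nc1ccccc1F`: 75 nM
- compound 3 `CCOC(=O)C1=CCCCC1S(=O)(=O)Nc1ccccc1Cl`: 12 nM

Compound 2, at 75 nM, has the second highest number of the three, with compound 1 its nearest neighbour and compound 3 its furthest.

The next compound is compound 4 `CCOC(=O)C1=CCCCC1S(=O)(=O)Nc1cccc(F)c1F`, still unmeasured in this assay. It differs from compound 2 as follows: fluoro in place of hydrogen on an aromatic carbon. The new fluoro stands on an aromatic carbon, ortho to a fluoro group and meta to a large group.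

Within the data shown here, no measured step makes this exact change, so the evidence is indirect. The closest is a 2.1-fold lower number from compound 1 to compound 2 (0.33 log units; beyond the scatter), where hydrogen replaces chloro on an aromatic carbon. It suggests that one more halogen on the ring of compound 2 could raise the number slightly. The other, a 6.3-fold lower number from compound 2 to compound 3 (0.80 log units; beyond the scatter), swaps one halogen for another and shows that the number can move further with the halogen on this ring, so the range is kept wide.

The direction is only weakly supported, and no step beyond the scatter is the likeliest outcome. The estimated step is a 1.2-fold higher number from compound 2 to compound 4 (0.08 log units; within the scatter). For compound 4 the estimated value is 90 nM, with an expected range of 30 nM to 270 nM.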

Compound 4, half-maximal inhibitory concentration: 140 nM
Beside the measured number, compound 4's estimate is 1.6-fold (0.19 log units) below it; low and high end bracket the measured number.
By their numbers in this assay, from the lowest: compound 3; then compounds 2, 4 and 1 (each within the scatter of the next, the first and the last beyond it).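

In this assay, fluoro in place of hydrogen on this aromatic carbon, ortho to a fluoro group and meta to a large group, gives a 1.9-fold higher number from compound 2 to compound 4 (0.27 log units; within the scatter). Among these compounds, this is the first reading at this carbon, which carries hydrogen in compounds 1, 2 and 3, and it shows that a second fluoro can stand here with no step beyond the scatter, unlike the chloro-to-hydrogen change in a 2.1-fold lower number from compound 1 to compound 2 (0.33 log units; beyond the scatter), which is made at a different ring carbon. Nothing at hand explains this result.

Going by these compounds, whether a chloro, methyl or methoxy group on this carbon would also stay within the scatter of compound 2 remains open, the more so as chloro in place of fluoro on an aromatic carbon gives a 6.3-fold lower number from compound 2 to compound 3 (0.80 log units; beyond the scatter). All four compounds keep the ethyl ester and the sulfonamide hydrogen of the shared core, so the compounds shown do not tell how a carboxylic acid or a longer chain in place of that ester would read on this ring pattern.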